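A few compounds are considered here, and "the series" means these few. Any claim that something is new, unique, unknown or untested is made for them only; others in the source may bear on it.

Compound 1 `CCC(C(=O)N1CCN(c2cccc(F)c2)CC1)N1C(=O)CCC1=O` gives 0% in a functional assay on the whole organism (strain Swiss) with Mus musculus as the target, in the maximal electroshock model, with a stated time of 0.5 h, at a dose of 100 mg/kg by the intraperitoneal route (on this read-out lower numbers stand for a weaker effect and higher numbers for a stronger effect at the one dose given), and stands level with compound 3 `CC(C(=O)N1CCN(c2cccc(F)c2)CC1)N1C(=O)CCC1=O`, which gives 0%; together they are the lowest of the three numbers, while compound 2 `CC(C(=O)N1CCN(c2ccccc2C(F)(F)F)CC1)N1C(=O)CCC1=O` gives 25%. Within the data shown here, the one measured step, no change at the digits printed from compound 1 to compound 3 (within the scatter), lies within the scatter. Compound 4 `CCC(C(=O)N1CCN(c2ccccc2)CC1)N1C(=O)CCC1=O` differs from compound 1 by hydrogen in place of fluoro on an aromatic carbon. Among the measured compounds shown here, no measured step touches a fluoro on the aromatic ring, so the change has no direct precedent; the only measured step was flat and compound 1 sits at the floor of the read-out. A step of about a number 5 percentage points higher from compound 1 to compound 4 (within the scatter) is therefore expected, which is no change beyond the scatter. Compound 4 is estimated at 5%, between 0% and 25%.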

Compound 4, a percentage reported as activity, at one dose (the size of the read-out at that dose, not a potency): 25%
Compound 4: the middle estimate sits 20 percentage points below what was measured, within the range that was stated.
By their numbers in this assay, from the lowest: compounds 1 and 3 (each within the scatter of the next); then compounds 2 and 4 (each within the scatter of the next).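

Going from 3-fluorophenyl to phenyl gives a number 25 percentage points higher from compound 1 to compound 4 (beyond the scatter) in this assay, the first step in the series to leave the scatter. The chain change gave no change at the digits printed from compound 1 to compound 3 (within the scatter), whereas this aromatic carbon is a place where the read-out responds, with hydrogen in place of fluoro lifting it off the floor. Nothing at hand accounts for this step. Still open, going by these compounds, is whether a chloro or methoxy group on the same aromatic carbon keeps the read-out of compound 4 or returns it to the floor, and how a longer chain on the core of compound 4 would read.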